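The source may report more compounds than this note shows. Statements on the series, on what has been measured and on what is new or still open speak of the compounds shown alone.

In a functional assay on NCI-H1299 cells (Homo sapiens) for inhibition, read by CCK-8 assay, with a stated time of 72 h, tested at 1 uM (a higher number here means more inhibition of growth at the concentration tested, a lower number less inhibition of growth), three compounds that share one core and differ only in the phenyl group on an amide-type nitrogen have been measured. Compound 1 `CN(C)C(=O)c1cc2cnc(Nc3ccc(NC(=O)C4(C(=O)Nc5ccc(Cl)cc5)CC4)cc3)nc2n1C1CCCC1`, with 4-chlorophenyl, gives 52.2%. Compound 2 `CN(C)C(=O)c1cc2cnc(Nc3ccc(NC(=O)C4(C(=O)Nc5ccccc5F)CC4)cc3)nc2n1C1CCCC1`, with 2-fluorophenyl, gives 70.2%. Compound 3 `CN(C)C(=O)c1cc2cnc(Nc3ccc(NC(=O)C4(C(=O)Nc5cccc(Br)c5)CC4)cc3)nc2n1C1CCCC1`, with 3-bromophenyl, gives 46.6%. It cannot be told apart from compound 1, as the within-scatter a number 5.6 percentage points lower from compound 1 to compound 3 (within the scatter) shows, whereas a number 23.6 percentage points lower from compound 2 to compound 3 (beyond the scatter) places it beyond the scatter under compound 2.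

Compound 4 `CN(C)C(=O)c1cc2cnc(Nc3ccc(NC(=O)C4(C(=O)Nc5ccc(O)cc5)CC4)cc3)nc2n1C1CCCC1` follows from compound 3 by one change: 4-hydroxyphenyl in place of 3-bromophenyl on an amide-type nitrogen. All three measured steps occur at the same place as this change. Besides the two already given, there is a number 18 percentage points higher from compound 1 to compound 2 (beyond the scatter), so the largest steps at this place are modest and the smallest lies within the scatter. Among the compounds with values here, none of the measured compounds carries a hydroxy group, so the data give no direct reading of 4-hydroxyphenyl. The closest comparison by name is 4-chlorophenyl in compound 1 at 52.2%. The expected step is therefore small, a number 5.4 percentage points higher from compound 3 to compound 4 (within the scatter), with no change beyond the scatter firmly expected. Compound 4 is estimated at 52%, with an expected range of 32% to 72%.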

Compound 4, percent growth inhibition at one concentration: 87.4%
The estimate for compound 4 lay 35.4 percentage points below the measured number, and the stated range ends below it.
By their numbers in this assay, from the lowest: compounds 3 and 1 (each within the scatter of the next); then compound 2; then compound 4.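

The 4-hydroxyphenyl group on the amide-type nitrogen places compound 4 above every halogen-bearing compound in this assay, with a number 40.8 percentage points higher from compound 3 to compound 4 (beyond the scatter) and a number 17.2 percentage points higher from compound 2 to compound 4 (beyond the scatter) in the same sentence of results, so this position can support more inhibition of growth than the three earlier phenyl groups revealed. The cleanest comparison is hydroxy in place of chloro on an aromatic carbon, where a number 35.2 percentage points higher from compound 1 to compound 4 (beyond the scatter) shows that this single substituent exchange, with the rest of the molecule unchanged, is enough to produce a large step. Nothing available explains the gain or ties it to the hydrogen-bond donor and acceptor that enter with the hydroxy group.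

From the compounds shown here alone, it remains open whether the gain is specific to hydroxy or would also appear with a methoxy group, an amine or a carboxylic acid in its place, and whether hydroxy elsewhere on the phenyl ring would keep it. Within the data shown here, because only this phenyl group varies, it is also unknown whether the gain would carry over to compounds with a different group elsewhere on the shared core.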